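Lengthening the Chain on a Shared Urea Core

The source may report more compounds than this note shows. Statements on the series, on what has been measured and on what is new or still open speak of the compounds shown alone.

Of the compounds shown here, three with one shared core have been measured in an ADME assay on the whole organism with Oryza sativa as the target, tested at 0.1 uM; a lower number here means a stronger effect, a higher number a weaker effect of the compound at the concentration tested. Compound 1 `CCc1ccc(NC(=O)N[C@@H](C)c2ccccc2)cc1` gives 99%. Compound 2 `CCCCc1ccc(NC(=O)N[C@H](C)c2ccccc2)cc1` gives 100%. Compound 3 `CCCCc1ccc(NC(=O)N[C@@H](C)c2ccccc2)cc1` gives 98%, which is the lowest of the three numbers, though its gaps to both of the others stay within the scatter. The step of a number 1 percentage points lower from compound 1 to compound 3 (within the scatter) shows that putting ethyl in place of hydrogen on a saturated chain carbon, two bonds along the chain from an aromatic carbon, leaves the read-out essentially unchanged. The step of a number 2 percentage points lower from compound 2 to compound 3 (within the scatter) is equally small, and it rests only on (the fact that compounds 2 and 3 differ only in the configuration as drawn).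

Compound 4 `CCCCCCCc1ccc(NC(=O)N[C@@H](C)c2ccccc2)cc1` has not yet been measured. It differs from compound 3 in a single place: propyl in place of hydrogen on a saturated chain carbon, four bonds along the chain from an aromatic carbon. Of the measured steps, only the chain extension a number 1 percentage points lower from compound 1 to compound 3 (within the scatter) bears on this change, and it stayed within the scatter. A step of about the same size, no change at the digits printed from compound 3 to compound 4 (within the scatter), is therefore expected here, with no movement beyond the scatter in either direction. For compound 4 the estimate in this assay is 98%, expected to fall between 90% and 100%.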

Compound 4, a percentage reported as activity, at one concentration (the size of the read-out at that concentration, not a potency): 100%
Estimate against measurement, compound 4: 2 percentage points below; low and high end bracket the measured number.
By their numbers in this assay, from the lowest: compounds 3, 1, 2 and 4 (each within the scatter of the next).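

In this assay, propyl in place of hydrogen on a saturated chain carbon, four bonds along the chain from an aromatic carbon, gives a number 2 percentage points higher from compound 3 to compound 4 (within the scatter), so a further extension of a chain that was already longer leaves the read-out as flat as the first extension did. Seen from the shortest chain in the set, the longest chain gives a number 1 percentage points higher from compound 1 to compound 4 (within the scatter), which shows that even this much larger addition to the shared core does not separate the compounds in this read-out. Nothing at hand offers an explanation for this lack of response to chain length.

Every chain shown is a plain saturated carbon chain, so it remains open whether an amine or a carboxylic acid in place of the propyl would move the number beyond the scatter. From the compounds shown here alone, with only one concentration to go on, it also remains open whether these chain lengths would separate at a different concentration.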